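Adding One Methyl: Expected Effect on Growth Inhibition

The compounds below may be only part of what the source reports. "The series", "measured", "known", "first", "only" and "open" are said of these compounds alone.

Measured so far:
compound 1, `CC1=C(C(C)CC(=O)OCC(C)COc2no[n+]([O-])c2S(=O)(=O)c2ccccc2)C(=O)c2c(O)cccc2C1=O`: 94.4%
compound 2, `CC1=C(CCC(=O)OCCCOc2no[n+]([O-])c2S(=O)(=O)c2ccccc2)C(=O)c2c(O)cccc2C1=O`: 96.8%

Both numbers come from a functional assay on MDA-MB-231 cells (Homo sapiens) for inhibition, read by MTT assay, with a stated time of 72 h, tested at 10 uM; a higher number here means more inhibition of growth at the concentration tested, a lower number less inhibition of growth. Compound 2 gives the larger of the two, but the gap to compound 1 lies within the usual scatter of the measurement, so the two compounds cannot be separated on these numbers. Compound 1 differs from compound 2 in more than one place, so nothing can be said about any single change between them beyond what the two values show.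

Compound 3, with structure `CC1=C(C(C)CC(=O)OCCCOc2no[n+]([O-])c2S(=O)(=O)c2ccccc2)C(=O)c2c(O)cccc2C1=O`, has not yet been measured. It differs from compound 2 by methyl in place of hydrogen on a saturated chain carbon bound to a double-bonded ring carbon and a saturated chain carbon. For the measured compounds named here, no pair of measured compounds isolates exactly this change, so the expected size of the step rests on compound 1, which carries the same methyl on its chain and still gives 94.4% in this assay. On that basis a step of a number 1.8 percentage points lower from compound 2 to compound 3 (within the scatter) is expected, that is, none beyond the scatter. Compound 3 is therefore estimated at 95%, with a range from 87% to 100%.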

Compound 3, percent growth inhibition at one concentration: 95.3%
Beside the measured number, compound 3's estimate is 0.3 percentage points below it; measured number inside the range.
By their numbers in this assay, from the lowest: compounds 1, 3 and 2 (each within the scatter of the next).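

For the compounds shown here, compound 3 gives the first direct reading of this change at this position: in this assay methyl in place of hydrogen on a saturated chain carbon bound to a double-bonded ring carbon and a saturated chain carbon gives a number 1.5 percentage points lower from compound 2 to compound 3 (within the scatter) and so the two compounds cannot be told apart. It also allows a reading at a second position, where hydrogen in place of methyl on a saturated chain carbon bound to two saturated chain carbons gives a number 0.9 percentage points higher from compound 1 to compound 3 (within the scatter) and there too the two compounds cannot be told apart. No other information here bears on why these compounds read alike.

All three compounds lie close to complete inhibition at a single concentration, so these numbers leave open whether a difference between them would appear at lower concentrations. Also open, as far as these compounds go, is how this assay would respond if the same chain carbon carried something other than hydrogen or methyl, such as an ethyl group, a phenyl ring, an amine or a carboxylic acid.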